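A few compounds are considered here, and "the series" means these few. Any claim that something is new, unique, unknown or untested is made for them only; others in the source may bear on it.

Measured so far in an in vitro assay on BTI-TN-5B1-4 cells for inhibition of Amine oxidase [flavin-containing] A (Homo sapiens), read by fluorescence, with a stated time of 15 min, tested at 100 uM; a lower number here means less inhibition, a higher number more inhibition at the concentration tested (going by the name of the read-out):
Compound 1 `Fc1ccc(-c2csc(N/N=C/c3ccccc3)n2)cc1` gives 40%.
Compound 2 `Fc1ccc(-c2csc(N/N=C/c3ccc(Cl)cc3)n2)cc1` gives 40%.
Compound 3 `Clc1ccc(/C=N/Nc2nc(-c3ccc(Cl)cc3)cs2)cc1` gives 40%.

Compound 2 therefore stands level with compound 1 and compound 3 at the digits shown; its reading lies within the scatter of both. Compound 4 `Cc1ccccc1/C=N/Nc1nc(-c2ccc(F)cc2)cs1` has not yet been measured. It differs from compound 2 by 2-methylphenyl in place of 4-chlorophenyl on a carbon with a double bond to nitrogen. Going by the values given here, two measured steps bear on this: no change at the digits printed from compound 1 to compound 2 (within the scatter) and no change at the digits printed from compound 2 to compound 3 (within the scatter), both within the scatter. Among the compounds with values here, neither of them touches the carbon with a double bond to nitrogen, so the new change has no direct precedent, yet every change seen so far has left the reading unmoved. Compound 4 is therefore expected at 40%, between 25% and 55%. The step expected is no change at the digits printed from compound 2 to compound 4 (within the scatter), none beyond the scatter.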

Compound 4, a percentage reported as inhibition, at one concentration (the size of the read-out at that concentration, not a potency): 40%
For compound 4 middle estimate and measured number coincide at the digits printed, within the range that was stated.
By their numbers in this assay, from the lowest: compounds 1, 2, 3 and 4 (each within the scatter of the next).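

In this assay, the aryl group on the carbon with a double bond to nitrogen now has a direct test: 2-methylphenyl in place of 4-chlorophenyl gives no change at the digits printed from compound 2 to compound 4 (within the scatter), and the added methyl alone gives no change at the digits printed from compound 1 to compound 4 (within the scatter). Methyl therefore joins chloro as a change on this ring that leaves the reading within the scatter. Nothing available explains this result.

As far as these compounds go, whether an amine or a carboxylic acid on this ring would move the reading stays open. A shared reading at one concentration also leaves open whether these compounds match in potency.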